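Swapping an aryl for an arylpropyl chain on the piperazine nitrogen

The source may hold more compounds than are shown below. What is called first, only, known or untested is meant among the compounds shown, and "the series" means these compounds.

Compound 2 `Nc1scc(CN2CCN(c3c(F)cc(F)cc3F)CC2)c1C(=O)c1ccc(Cl)cc1` and compound 1 `Nc1scc(CN2CCN(c3ccc(Cl)cc3F)CC2)c1C(=O)c1ccc(Cl)cc1` share one core and were both tested in a functional assay on CHO cells with adenosine receptor A1 (Homo sapiens) as the target, read by cAMP accumulation and immunoassay, with a stated time of 6 min, tested at 1 uM; on this read-out lower numbers stand for a stronger effect and higher numbers for a weaker effect at the one concentration tested. There compound 1 gives -57% and compound 2 gives -56%. Going by the values given here, compound 2 holds the highest of the two numbers, but its nearest neighbour sits only one point away, so the two are indistinguishable within the scatter; the single measured step, a number 1 percentage points higher from compound 1 to compound 2 (within the scatter), is an exchange of one aryl group for another on the same ring nitrogen.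

Compound 3 `Nc1scc(CN2CCN(CCCc3ccc(Cl)cc3)CC2)c1C(=O)c1ccc(Cl)cc1` is not yet measured. It differs from compound 2 in this way: 3-(4-chlorophenyl)propyl in place of 2,4,6-trifluorophenyl on an amine nitrogen in a ring. Among the compounds with values here, no measured step covers a change from an aryl group to a chain of this kind, so the only guidance is that the one aryl exchange seen so far left the read-out unchanged. For compound 3 the expected step is therefore a number 11 percentage points higher from compound 2 to compound 3 (beyond the scatter), with considerable uncertainty. Compound 3 is estimated at -45%, within a range from -80% to -5%.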

Compound 3, a percentage reported as activity, at one concentration (the size of the read-out at that concentration, not a potency): -30%
Estimate against measurement, compound 3: 15 percentage points below, and the stated range covers the measured number.
By their numbers in this assay, from the lowest: compounds 1 and 2 (each within the scatter of the next); then compound 3.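

In this assay, the ring nitrogen responds to a change of group type in a way the aryl exchange did not show: the 3-(4-chlorophenyl)propyl group gives a number 26 percentage points higher from compound 2 to compound 3 (beyond the scatter) and a number 27 percentage points higher from compound 1 to compound 3 (beyond the scatter) in place of the two fluorinated aryl groups. At the one concentration tested, the effect is therefore weaker with this chain on the nitrogen, although compound 3 still gives -30% and so keeps a negative read-out. Nothing measured here accounts for this difference.

The chain and the substituents on the aromatic ring change together, so the compounds shown leave open how much of the step belongs to the propyl chain itself. A 3-(2,4,6-trifluorophenyl)propyl group would separate the two, and a shorter 4-chlorobenzyl group would show whether chain length matters at this nitrogen.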